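Placing the acid on a cyclopropane ring

A few compounds are considered here, and "the series" means these few. Any claim that something is new, unique, unknown or untested is made for them only; others in the source may bear on it.

The agonist read-out here is a functional assay on CHO cells for agonist activity at Free fatty acid receptor 1 (Homo sapiens), read by a luciferase reporter; on this read-out higher numbers stand for larger maximal responses and lower numbers for smaller maximal responses. Three compounds share this measurement. Compound 1 `O=C(O)c1ccc(NCc2cccc(Oc3ccccc3)c2)cc1` gives 86%. Compound 2 `Cc1nc(-c2ccc(C(F)(F)F)cc2)sc1CNc1ccc(CC(=O)O)cc1` gives 18%, and compound 3 `Cc1nc(-c2ccc(C(F)(F)F)cc2)sc1CNc1ccc(C(C)CC(=O)O)cc1` gives 109%. Compound 1 thus stands second of the three: compound 3 lies higher and compound 2 lies lower, both gaps being beyond the usual scatter.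

Compound 4 `O=C(O)[C@@H]1C[C@H]1c1ccc(NCc2cccc(Oc3ccccc3)c2)cc1` is built from compound 1 by one change, (2-carboxycyclopropyl in place of carboxy on an aromatic carbon). For the measured compounds named here, the only measured step that resembles it is the one within the other pair, where 1-(carboxymethyl)ethyl replaced carboxymethyl on an aromatic carbon and the maximal response rose sharply: a number 91 percentage points higher from compound 2 to compound 3 (beyond the scatter). That step enlarged the acid-bearing group on a different core, so it is a loose guide rather than a direct precedent. Still, it points upward, and compound 1 already gives a high response, leaving limited room above it in this assay.

The step expected is a number 12 percentage points higher from compound 1 to compound 4 (beyond the scatter), small and within or near the scatter. Compound 4 is therefore expected to give 98%, with a likely range from 80% to 118%.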

Compound 4, largest response reached (reported as percent of maximum), in percent of the reference or control that the assay uses: 64%
For compound 4 the middle estimate is 34 percentage points above the measured one; the whole stated range lies above it.
By their numbers in this assay, from the lowest: compound 2; then compound 4; then compound 1; then compound 3.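

In this assay, putting 2-carboxycyclopropyl in place of carboxy on the aromatic carbon para to a large group gives a number 22 percentage points lower from compound 1 to compound 4 (beyond the scatter) on the core of compound 1. At this position, then, a larger group carrying the acid lowers the maximal response without abolishing it. The earlier step of a number 91 percentage points higher from compound 2 to compound 3 (beyond the scatter) also enlarged the acid-bearing group, but on a different core and with the opposite result, so the direction seen there does not carry over and no single trend holds across these two pairs. Nothing at hand explains the drop at compound 4.

The compounds shown leave open whether the ring itself or simply the added length lowers the response, which an open 2-carboxyethyl chain on the core of compound 1 would help to separate. They also leave open how the two defined stereocentres of compound 4 contribute, and whether the 2-carboxycyclopropyl group would behave the same way on the core of compound 3.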